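The compounds below may be only part of what the source reports. "The series", "measured", "known", "first", "only" and "open" are said of these compounds alone.

Values in a functional assay on P388 cells (Mus musculus) for antiproliferative activity, read by colorimetric assay and MTT assay (on this read-out lower numbers stand for stronger inhibition and higher numbers for weaker inhibition), for the compounds measured so far:

- compound 1 `O=S(=O)(Nc1cccc2c(Cl)c[nH]c12)c1ccc(Cl)cc1` gives 4.3 ug/mL here
- compound 2 `O=[N+]([O-])c1ccc(S(=O)(=O)Nc2cccc3c(Cl)c[nH]c23)cc1` gives 2.3 ug/mL here
- compound 3 `Nc1ccc(S(=O)(=O)Nc2cccc3c(Cl)c[nH]c23)cc1` gives 0.81 ug/mL here

Compound 3 has the lowest of these three numbers and is the strongest inhibitor of the set. Its steps from both others lie beyond the scatter: a 5.3-fold lower number from compound 1 to compound 3 (0.72 log units; beyond the scatter) and a 2.8-fold lower number from compound 2 to compound 3 (0.45 log units; beyond the scatter) are both modest.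

Within the data shown here, the next compound, compound 4 `Cc1ccc(NS(=O)(=O)c2ccc(N)cc2)c2[nH]cc(Cl)c12`, has no measurement yet. It carries methyl in place of hydrogen on an aromatic carbon of the core methyl in place of hydrogen on an aromatic carbon and is otherwise the same as compound 3.

Among the measured compounds shown here, no measured step touches that carbon or involves a methyl group. The three steps swap chloro, nitro and amino at a different place, so they show only how far a single small swap has moved the number in this set. The smallest is a 1.9-fold lower number from compound 1 to compound 2 (0.27 log units; within the scatter) and the largest is a 5.3-fold lower number from compound 1 to compound 3 (0.72 log units; beyond the scatter) for comparison.

The data give no direction for adding methyl, so no step beyond the scatter is expected, although a modest shift either way remains possible. The expected step is a 1.2-fold lower number from compound 3 to compound 4 (0.06 log units; within the scatter) on this estimate. In this assay compound 4 is estimated at 0.7 ug/mL with an expected range from 0.2 ug/mL to 2.5 ug/mL around that middle.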

Compound 4, half-maximal inhibitory concentration: 0.37 ug/mL
The estimate for compound 4 lay 1.9-fold (0.28 log units) above the measured number, within the range that was stated.
By their numbers in this assay, from the lowest: compound 4; then compound 3; then compounds 2 and 1 (each within the scatter of the next).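

In this assay, among these compounds, methyl in place of hydrogen on an aromatic carbon of the core gives a 2.2-fold lower number from compound 3 to compound 4 (0.34 log units; beyond the scatter) and is the first step measured at this carbon, para to a large group. The earlier steps shown here all swapped chloro, nitro and amino at a different place, so they said nothing about whether this carbon could carry anything other than hydrogen. Here it carries one extra carbon atom with no loss of inhibition and a modest gain, though nothing measured in this set explains that gain.

Going by these compounds, a single methyl group shows only one point at this position, so it remains open whether an ethyl group, a methoxy group or an amine on the same carbon would lower the number further or raise it again. On these data alone, it is also open whether methyl would give a similar step with the nitro group of compound 2 or the chloro group of compound 1 in place of the amino group shared by compound 3 and compound 4.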